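Bromo-substituted amide series: cyclohexyl amide step from compound 2

The source may hold more compounds than are shown below. What is called first, only, known or untested is meant among the compounds shown, and "the series" means these compounds.

Measured:
compound 1 `CN(C)CCCNc1c(C(=O)NCc2ccc(F)cc2)nc(Br)c2cccnc12` – 7000 nM
compound 2 `COc1cccc(CNC(=O)c2nc(Br)c3cccnc3c2N[C@H]2CC[C@H](N)CC2)c1` – "not determined" (no result reported)

In a functional assay on MCF7 cells (Homo sapiens) for cytotoxicity, read by MTT assay, with a stated time of 72 h (a higher number here means a weaker inhibitor, a lower number a stronger inhibitor), compound 1 gives 7000 nM. Compound 2 stands without a number in this assay, so no anchor exists for the following step. Compound 3 `N[C@H]1CC[C@H](Nc2c(C(=O)NC3CCCCC3)nc(Br)c3cccnc23)CC1` differs from compound 2 by cyclohexyl in place of 3-methoxybenzyl on an amide-type nitrogen; 3-methoxybenzyl leaves and cyclohexyl enters. Going by the values given here, with no measured step between these compounds, any step size in this assay is a guess; the only measured compound, compound 1, carries a different amine and a different amide substituent, so a large shift in either direction would not be surprising. Compound 3 is expected to give about 5000 nM, within an estimated range of 1000 nM to 25000 nM.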

Compound 3, half-maximal inhibitory concentration: 5200 nM
Compound 3: middle estimate off by 1.0-fold (0.02 log units), on the low side; low and high end bracket the measured number.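

In this assay no step can be read between compound 2, which has no number, and compound 3. From the compounds shown here alone, the effect of exchanging 3-methoxybenzyl for cyclohexyl on the amide-type nitrogen stays open. No supporting evidence bears on this result.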